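Methyl to Chloro on the Carboxyphenyl Ring

The compounds below may be only part of what the source reports. "The series", "measured", "known", "first", "only" and "open" are said of these compounds alone.

The series shares a core carrying a cyclopentyl-substituted lactam linked through a benzyloxy unit to a biaryl group. Compound 1 `O=C(O)c1cc(-c2cccc(COc3ccc4c(c3)CN(C3CCCC3)C4=O)c2)ccc1O` gives 90.1% in an assay on HEK293 cells for positive allosteric modulation of metabotropic glutamate receptor 2 (Rattus norvegicus), read by thallium flux; on this read-out lower numbers stand for smaller maximal responses and higher numbers for larger maximal responses. Compound 2 `O=C1c2ccc(OCc3cccc(-c4ccc(C(F)(F)F)cc4F)c3)cc2CN1C1CCCC1` belongs to the same set, and in this assay compound 2 shows "not determined" (no result reported), so no number is available for it. Going by the values given here, compound 3 `Cc1ccc(C(=O)O)cc1-c1cccc(COc2ccc3c(c2)CN(C2CCCC2)C3=O)c1` gives 80.8% in this assay, the lower of the two numbers in hand, and its only neighbour is compound 1: the step of a number 9.3 percentage points lower from compound 1 to compound 3 (within the scatter) is within the scatter, so no order between the two can be read.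

Compound 4 `O=C(O)c1ccc(Cl)c(-c2cccc(COc3ccc4c(c3)CN(C3CCCC3)C4=O)c2)c1` differs from compound 3 in one place: chloro in place of methyl on an aromatic carbon. Among the compounds with values here, the single measured step, a number 9.3 percentage points lower from compound 1 to compound 3 (within the scatter), changes the same aromatic ring, yet it swaps the whole substituent pattern and stays within the scatter; it says little about a chloro in place of a methyl on its own. Within the data shown here, the only guidance the numbers give is that the maximal response so far tolerated changes on that ring without moving beyond the scatter.

For compound 4 the expected step of a number 1.2 percentage points higher from compound 3 to compound 4 (within the scatter) is therefore no change beyond the scatter. Compound 4 is estimated at 82%, in a range from 66% to 98% in this assay.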

Compound 4, largest response reached (reported as percent of maximum), in percent of the reference or control that the assay uses: 93.9%
For compound 4 the middle estimate is 11.9 percentage points below the measured one; measured number inside the range.
By their numbers in this assay, from the lowest: compounds 3, 1 and 4 (each within the scatter of the next, the first and the last beyond it).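

Chloro in place of methyl gives a number 13.1 percentage points higher from compound 3 to compound 4 (beyond the scatter) in this assay, so this aromatic carbon, ortho to a large group and para to a carboxy group, responds measurably to the exchange of a single heavy atom, which the earlier step on this ring, within the scatter, did not show. The other new step, a number 3.8 percentage points higher from compound 1 to compound 4 (within the scatter), leaves 5-carboxy-2-chlorophenyl and 3-carboxy-4-hydroxyphenyl without any order between them, so two differently substituted carboxyphenyl rings cannot be told apart on this read-out, while the methyl and chloro versions of the same ring can. The compounds shown offer no measurement that would explain the difference between methyl and chloro at this carbon.

As far as these compounds go, it remains open whether a methoxy, a fluoro or a nitrile on the same carbon would track the chloro or the methyl result in this assay. From the compounds shown here alone, it is equally open whether an amine or a tetrazole in place of the carboxy group would preserve the maximal response when the chloro stays in place.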